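The source may hold more compounds than are shown below. What is called first, only, known or untested is meant among the compounds shown, and "the series" means these compounds.

Compound 1 `O=c1ccn(CCN2CCCCC2)c(CO)c1O` gives 9.28 in a physicochemical assay for acid dissociation, using potentiometric titration.
Compound 2 `Cn1cc(O)c(=O)cc1CN1CCCCC1` gives 8.85 in this assay.
Compound 3 `CCc1c(O)c(=O)ccn1CCCn1ccnc1` gives 9.71 in this assay.

Among these three numbers compound 3 stands highest. Its nearest neighbour is compound 1, whose number is lower by a margin beyond the scatter, and compound 2 lies further below it, again beyond the scatter. Compound 4 `CCc1c(O)c(=O)ccn1CCN(C)C` has not yet been measured in this assay. It differs from compound 3 in a single place: dimethylamino in place of (1H-imidazol-1-yl)methyl on a saturated chain carbon, two bonds along the chain from an aromatic nitrogen. Going by the values given here, no pair of the measured compounds differs in only one place, so no step of this kind can be read off directly. The nearest point of comparison is compound 1, which also carries a saturated chain on the aromatic nitrogen ending in a nitrogen-containing group and gives 9.28, a number below that of compound 3. On this basis a modest downward step from compound 3 to compound 4 is expected in this assay, of a size near the edge of the scatter and not larger than the gap between compound 3 and compound 1. Compound 4 is therefore estimated to give about 9.4 in this assay, with a likely range from 9 to 9.8. The expected step is a number 0.31 log units lower from compound 3 to compound 4 (beyond the scatter).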

Compound 4, acid dissociation constant: 9.66
The estimate for compound 4 lay 0.26 log units below the measured number, within the range that was stated.
By their numbers in this assay, from the lowest: compound 2; then compound 1; then compounds 4 and 3 (each within the scatter of the next).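

At the place tested here, on a saturated chain carbon, two bonds along the chain from an aromatic nitrogen, putting dimethylamino in place of (1H-imidazol-1-yl)methyl gives, in this assay, a number 0.05 log units lower from compound 3 to compound 4 (within the scatter), so this exchange does not separate the two compounds by this read-out. Going by these compounds alone, this is the first comparison that isolates a single change, and it shows that a group of 6 heavy atoms with a five-membered aromatic ring can give way to a group of 3 heavy atoms with no ring while the two numbers remain within the scatter of each other. No independent evidence bears on why the two compounds agree so closely.

Compounds 1 and 2 remain joined to the others by no single-place step, so the effects of the other differences in structure cannot be read from the numbers shown. Going by these compounds, it also remains open whether the number would stay within the scatter with a carboxylic acid at this place, or with a longer chain carrying the dimethylamino group.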